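Removing a Hydroxy Group From a Weak Antiproliferative Amide

This account rests on a few compounds, and the source may have more. Where it says the series, first, only, none or still open, it means among the compounds named here.

Compound 2, `O=C(/C=C/c1ccc(O)cc1)Nc1cc2c(Nc3ccc(Cl)c(Cl)c3)ncnc2s1`, was tested in a functional assay on MCF7 cells (Homo sapiens) for antiproliferative activity, read by MTT assay, with a stated time of 48 h (on this read-out lower numbers stand for stronger inhibition and higher numbers for weaker inhibition), and gave 60600 nM. That is the highest of the two numbers measured here. Compound 1, `COc1ccc(/C=C/C(=O)Nc2cc3ncnc(Nc4ccc(F)c(Cl)c4)c3s2)cc1`, gives 29100 nM in this assay, a lower number, so compound 1 inhibits cell growth more strongly than compound 2. These two compounds differ in more than one place, so their gap cannot be tied to any single change.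

Compound 3, `O=C(/C=C/c1ccccc1)Nc1cc2c(Nc3ccc(Cl)c(Cl)c3)ncnc2s1`, has not been measured. It differs from compound 2 in one place only: hydrogen in place of hydroxy on an aromatic carbon. The hydroxy sits on an aromatic carbon of a six-membered aromatic ring of carbon only, para to a large group, and hydrogen takes its place, so that 4-hydroxyphenyl becomes phenyl.

Within the data shown here, no measured pair here shows what this change does, so its direction is open. For compound 3 the expected step is modest, a 1.5-fold lower number from compound 2 to compound 3 (0.18 log units; within the scatter), leaning toward a somewhat lower number. Compound 3 is estimated at 40000 nM in this assay, with a range from 12000 nM to 130000 nM.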

Compound 3, half-maximal inhibitory concentration: 15300 nM
For compound 3 the middle estimate is 2.6-fold (0.42 log units) above the measured one; the measured number falls inside the stated range.
By their numbers in this assay, from the lowest: compounds 3 and 1 (each within the scatter of the next); then compound 2.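

In this assay, among these compounds, the single change from 4-hydroxyphenyl to phenyl gives a 4.0-fold lower number from compound 2 to compound 3 (0.60 log units; beyond the scatter), the first comparison here in which a gap can be tied to one place in the structure. The step lies beyond the usual scatter, so this position on the six-membered aromatic ring affects the result, and in this pair the hydroxy is not needed for inhibition of cell growth, since the compound without it gives the lower number. No measurement in hand bears on why removing this one heavy atom has this effect, so the step stands as an observation without an explanation.

From the compounds shown here alone, what an amine or a carboxylic acid on this same aromatic carbon would do remains open, so this one step cannot show how the result depends on the kind of group placed there. Going by these compounds, it is also open whether the same change would give a step of similar size on a different background, such as the one carrying the halogenated aniline of compound 1.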